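The compounds below may be only part of what the source reports. "The series", "measured", "known", "first", "only" and "open" are said of these compounds alone.

Two compounds carry numbers here, both sharing the same core. Compound 1 `O=C(CN(c1ncnc2c1ncn2C1CCCCO1)C1CC1)N[C@@H](CC(=O)OCc1ccccc1)C(=O)OCc1ccccc1` gives, in a functional assay on the whole organism (Tail, strain ICR) with Mus musculus as the target, in the tail flick test, with a stated time of 60 min, at a dose of 25 umol/kg by the oral route (on this read-out lower numbers stand for a weaker effect and higher numbers for a stronger effect at the one dose given), a reading of 38.2%. Among the measured compounds shown here, compound 2 `CC(C)C[C@H](NC(=O)CN(c1ncnc2c1ncn2C1CCCCO1)C1CC1)C(=O)OCc1ccccc1` gives 34.2% in this assay, so the two readings sit within the usual scatter of one another and neither can be called stronger; the one measured step, a number 4 percentage points lower from compound 1 to compound 2 (within the scatter), confirms this.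

Compound 3 `CC(C)[C@H](NC(=O)CN(c1ncnc2c1ncn2C1CCCCO1)C1CC1)C(=O)OCc1ccccc1` is not yet measured. It differs from compound 2 by isopropyl in place of isobutyl on a saturated chain carbon bound to an amide-type nitrogen and a carbonyl carbon, a small trimming of the side chain on the saturated chain carbon bound to an amide-type nitrogen and a carbonyl carbon. For the measured compounds named here, no measured step touches this particular exchange; the only step available, from benzyloxycarbonyl to isopropyl, was itself within the scatter, so nothing in the data points to a shift of any size. Compound 3 is therefore expected to read close to compound 2, a step of a number 1.2 percentage points lower from compound 2 to compound 3 (within the scatter) that lies within the scatter. The estimate for compound 3 in this assay is 33%, with a likely range from 20% to 46%.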

Compound 3, a percentage reported as activity, at one dose (the size of the read-out at that dose, not a potency): 34.9%
Beside the measured number, compound 3's estimate is 1.9 percentage points below it; measured number inside the range.
By their numbers in this assay, from the lowest: compounds 2, 3 and 1 (each within the scatter of the next).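

In this assay, the side chain on the saturated chain carbon bound to an amide-type nitrogen and a carbonyl carbon now comes in three forms, and their readings cannot be told apart. Isopropyl in place of isobutyl gives a number 0.7 percentage points higher from compound 2 to compound 3 (within the scatter), and isopropyl in place of (benzyloxycarbonyl)methyl gives a number 3.3 percentage points lower from compound 1 to compound 3 (within the scatter), so at this one dose neither a small exchange nor a larger one stands clear of the scatter. No measurement at hand speaks to the reason for this.

From the compounds shown here alone, whether a carboxylic acid or an amine on this carbon would give a reading beyond the scatter stays open. The same holds for a longer chain, and for whether these three compounds would separate at another dose.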